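The compounds below may be only part of what the source reports. "The series", "measured", "known", "first", "only" and "open" are said of these compounds alone.

In a functional assay on A549 cells (Homo sapiens) for antiproliferative activity, read by MTT assay, with a stated time of 24 h (a lower number here means a stronger inhibitor, a higher number a weaker inhibitor), compound 1 (`Cc1ccc(-c2nn(-c3ccccc3)cc2-c2nc3ccccc3n2S(=O)(=O)c2ccc(C(F)(F)F)cc2)cc1`) gives 1460 nM and compound 2 (`Cc1ccc(C)c(S(=O)(=O)n2c(-c3cn(-c4ccccc4)nc3-c3ccc(C(F)(F)F)cc3)nc3ccccc32)c1`) gives 150 nM. Compound 3 (`O=S(=O)(c1ccc(F)cc1)n1c(-c2cn(-c3ccccc3)nc2-c2ccc(C(F)(F)F)cc2)nc2ccccc21`) gives 1740 nM, within the scatter of compound 1 and well above compound 2. The next compound, compound 4 (`O=S(=O)(c1ccc(C(F)(F)F)cc1)n1c(-c2cn(-c3ccccc3)nc2-c2ccc(C(F)(F)F)cc2)nc2ccccc21`), carries trifluoromethyl in place of fluoro on an aromatic carbon, para to a large group: trifluoromethyl in place of fluoro on an aromatic carbon. Among the measured compounds shown here, the only measured step on this part of the structure is a 12-fold higher number from compound 2 to compound 3 (1.06 log units; beyond the scatter), with 4-fluorophenyl in place of 2,5-dimethylphenyl on a sulfonyl sulfur. That large step exchanged the whole aryl group, so it bears only loosely on a change from 4-fluorophenyl to 4-(trifluoromethyl)phenyl. Closer evidence comes from compound 1, which has 4-(trifluoromethyl)phenyl on its sulfonyl sulfur and gives 1460 nM, although it also differs from compound 4 elsewhere. No shift beyond the scatter is therefore expected in this assay. The expected step is a 1.2-fold lower number from compound 3 to compound 4 (0.06 log units; within the scatter). For compound 4 the estimated value is 1500 nM, with an expected range of 500 nM to 4500 nM.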

Compound 4, half-maximal inhibitory concentration: 860 nM
Beside the measured number, compound 4's estimate is 1.7-fold (0.24 log units) above it; the measured number falls inside the stated range.
By their numbers in this assay, from the lowest: compound 2; then compounds 4, 1 and 3 (each within the scatter of the next, the first and the last beyond it).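

In this assay, among the compounds shown here, trifluoromethyl in place of fluoro on an aromatic carbon, para to a large group, is the first change read within a single sulfonyl aryl group, and it gives a 2.0-fold lower number from compound 3 to compound 4 (0.31 log units; beyond the scatter), a modest step. This change does not close the gap to the 2,5-dimethylphenyl group of compound 2, since 4-(trifluoromethyl)phenyl in its place still gives a 5.7-fold higher number from compound 2 to compound 4 (0.76 log units; beyond the scatter). On the other aryl group, trifluoromethyl in place of methyl gives a 1.7-fold lower number from compound 1 to compound 4 (0.23 log units; within the scatter), so no shift beyond the scatter is seen for that exchange.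

Still open, as far as these compounds go, is whether the lower number of compound 2 depends on one of its two methyl groups or on both, and how an amine or a carboxylic acid in place of fluoro would read in this assay. No supporting evidence is available to explain these steps.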